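The source may report more compounds than this note shows. Statements on the series, on what has been measured and on what is new or still open speak of the compounds shown alone.

Measured compounds:
compound 1 `Cc1nc(S(C)(=O)=O)ccc1Oc1ncnc(OC2CCN(C(=O)OC(C)C)CC2)c1F` — 142 nM
compound 2 `Cc1nc(S(C)(=O)=O)ccc1Oc1ncnc(OC2CCN(C(=O)OC3(C(F)(F)F)COC3)CC2)c1F` — 342 nM
compound 3 `Cc1nc(S(C)(=O)=O)ccc1Oc1ncnc(OC2CCN(C(=O)SC3CCC3)CC2)c1F` — 77.4 nM

In a functional assay on isolated protein for inhibition of Glucose-dependent insulinotropic receptor (Rattus norvegicus), read by HTRF and cAMP accumulation (a higher number here means that more compound is needed for the effect, a lower number that less compound is needed), compound 1 gives 142 nM, which puts it second highest of the three numbers. Its nearest neighbour is compound 3, and the difference a 1.8-fold lower number from compound 1 to compound 3 (0.26 log units; within the scatter) stays within the usual scatter; the furthest is compound 2, reached by a 2.4-fold higher number from compound 1 to compound 2 (0.38 log units; beyond the scatter), a modest step beyond the scatter.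

Compound 4 `CCC(F)(F)C(=O)N1CCC(Oc2ncnc(Oc3ccc(S(C)(=O)=O)nc3C)c2F)CC1` differs from compound 1 at the same carbonyl carbon that the other two changes touched: 1,1-difluoropropyl in place of isopropoxy on a carbonyl carbon

Among the compounds with values here, two measured steps bear on this position. Exchanging the group on the carbonyl carbon for a larger fluorinated oxygen-linked one gave a 2.4-fold higher number from compound 1 to compound 2 (0.38 log units; beyond the scatter), while exchanging it for a sulfur-linked ring gave a 1.8-fold lower number from compound 1 to compound 3 (0.26 log units; within the scatter). Both moves stayed modest, so for compound 4 no shift beyond the scatter is expected in this assay; the estimated step is a 1.1-fold higher number from compound 1 to compound 4 (0.05 log units; within the scatter). Compound 4 is therefore expected to give about 160 nM, within a range of 60 nM to 420 nM.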

Compound 4, half-maximal effective concentration: 69.2 nM
Beside the measured number, compound 4's estimate is 2.3-fold (0.36 log units) above it, and the stated range covers the measured number.
By their numbers in this assay, from the lowest: compounds 4, 3 and 1 (each within the scatter of the next, the first and the last beyond it); then compound 2.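

At the carbonyl carbon, 1,1-difluoropropyl in place of isopropoxy gives a 2.1-fold lower number from compound 1 to compound 4 (0.31 log units; beyond the scatter), the first step down from compound 1 at this place to lie beyond the scatter, although it stays modest. An oxygen or sulfur link on the carbonyl carbon is therefore not required for activity in this assay, since this carbon-linked group, with no hydrogen-bond acceptor, matches the sulfur-linked ring, with a 1.1-fold lower number from compound 3 to compound 4 (0.05 log units; within the scatter). It also sits clearly apart from the fluorinated oxetane group, with a 4.9-fold lower number from compound 2 to compound 4 (0.69 log units; beyond the scatter).

Nothing shown gives a reason for these differences. From the compounds shown here alone, whether a plain propyl chain or a cyclopropyl ring on the same carbonyl carbon would give a number like that of compound 4 remains open.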